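This account rests on a few compounds, and the source may have more. Where it says the series, first, only, none or still open, it means among the compounds named here.

Measured so far:
compound 1, `O=C(O)c1csc([C@H]2CC[C@@H]3[C@@H](CCCCCOc4ccccc4)[C@H](O)C[C@@H]3O2)n1`: 28 nM
compound 2, `O=C(O)c1csc([C@H]2CC[C@@H]3[C@@H](COc4cccc(F)c4)[C@H](O)C[C@@H]3O2)n1`: 5.4 nM

In a functional assay on CHO cells for agonist activity at prostaglandin E2 receptor EP2 subtype (Homo sapiens), read by HTRF and cAMP accumulation, with a stated time of 30 min (on this read-out lower numbers stand for an effect already at smaller amounts and higher numbers for an effect only at larger amounts of compound), compound 2 has the lower of the two numbers; compound 1 gives 28 nM, a higher value that lies beyond the usual scatter. Compound 3, `O=C(O)c1csc([C@H]2CC[C@@H]3[C@@H](CCCOc4ccccc4)[C@H](O)C[C@@H]3O2)n1`, has not yet been measured. It differs from compound 2 by 2-phenoxyethyl in place of 3-fluorophenoxy on a saturated chain carbon bound to a saturated ring carbon. Because compound 1 gives 28 nM with a longer phenoxy-bearing chain, a step upward is expected from compound 2 to compound 3, a 2.4-fold higher number from compound 2 to compound 3 (0.38 log units; beyond the scatter), on this assay, possibly beyond the scatter. Compound 3 is estimated at 13 nM, ranging from 4 nM to 40 nM.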

Compound 3, half-maximal effective concentration: 10 nM
Compound 3: the middle estimate sits 1.3-fold (0.11 log units) above what was measured, within the range that was stated.
By their numbers in this assay, from the lowest: compounds 2 and 3 (each within the scatter of the next); then compound 1.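

In this assay, 2-phenoxyethyl in place of 3-fluorophenoxy on this saturated chain carbon gives a 1.9-fold higher number from compound 2 to compound 3 (0.27 log units; within the scatter), so at this position the two groups cannot be told apart. The chain itself does register: phenoxy in place of 2-phenoxyethyl, three bonds along the chain from a saturated ring carbon, gives a 2.8-fold lower number from compound 1 to compound 3 (0.45 log units; beyond the scatter), and compound 3 with the shorter chain has the lower number. Nothing measured here explains either step. Still open, going by these compounds, is what 3-fluorophenoxy would do on the longer chains, and how an amine in place of the phenoxy group would read.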